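The compounds below may be only part of what the source reports. "The series", "measured", "known", "first", "only" and "open" are said of these compounds alone.

Measured compounds:
compound 1 `COc1cccc(/C=C/C(=O)NNC(=O)c2ccc3c(c2)OCCO3)c1` — 398000 nM
compound 2 `COc1ccc(/C=C/C(=O)NNC(=O)c2ccc3c(c2)OCCO3)cc1` — 319000 nM
compound 3 `O=C(/C=C/c1ccccc1[N+](=O)[O-])NNC(=O)c1ccc2c(c1)OCCO2` — 257000 nM

In an ADME assay on cells (Macrophage) for cytotoxicity, read by MTT assay, with a stated time of 24 h (on this read-out lower numbers stand for higher toxicity in this test and higher numbers for lower toxicity in this test), compound 2 gives 319000 nM, the second highest of these three numbers; both neighbours sit within the scatter of it: a 1.2-fold lower number from compound 2 to compound 3 (0.09 log units; within the scatter) and a 1.2-fold lower number from compound 1 to compound 2 (0.10 log units; within the scatter).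

Compound 4 `O=C(/C=C/c1cccc(Cl)c1)NNC(=O)c1ccc2c(c1)OCCO2` has not yet been measured there. It differs from compound 2 in one place: 3-chlorophenyl in place of 4-methoxyphenyl on a double-bonded chain carbon bound to a double-bonded chain carbon. For the measured compounds named here, the steps that bear on this change are the other swaps of the aryl group on the same chain carbon, a 1.2-fold lower number from compound 1 to compound 2 (0.10 log units; within the scatter), a 1.5-fold lower number from compound 1 to compound 3 (0.19 log units; within the scatter) and a 1.2-fold lower number from compound 2 to compound 3 (0.09 log units; within the scatter), each within the scatter. A comparable step is therefore expected here, none beyond the scatter: a 1.1-fold lower number from compound 2 to compound 4 (0.03 log units; within the scatter). Compound 4 is estimated at 300000 nM, with a range from 180000 nM to 500000 nM.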

Compound 4, half-maximal cytotoxic concentration: 391000 nM
Compound 4: middle estimate off by 1.3-fold (0.12 log units), on the low side, within the range that was stated.
By their numbers in this assay, from the lowest: compounds 3, 2, 4 and 1 (each within the scatter of the next).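

With 3-chlorophenyl in place of 4-methoxyphenyl on this chain carbon, this assay stays within the scatter (a 1.2-fold higher number from compound 2 to compound 4 (0.09 log units; within the scatter)), and the same holds against the 2-nitrophenyl group (a 1.5-fold higher number from compound 3 to compound 4 (0.18 log units; within the scatter)). Chloro in place of methoxy on an aromatic carbon also stays within the scatter (a 1.0-fold lower number from compound 1 to compound 4 (0.01 log units; within the scatter)), so a chlorine-bearing aryl group reads here like the methoxy and nitro ones across these four compounds. Nothing at hand gives a reason for this.

Still open, as far as these compounds go, is whether an aryl group carrying an amine or a carboxylic acid, or a longer chain in place of the aryl group, would give a step beyond the scatter.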